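Methoxycarbonyl in place of acetyl on compound 2

The source may hold more compounds than are shown below. What is called first, only, known or untested is meant among the compounds shown, and "the series" means these compounds.

In a functional assay on the whole organism for agonist activity, with Mus musculus as the target (a higher number here means that more compound is needed for the effect, a lower number that less compound is needed), compound 2 `CC(=O)N(C)C(C)C#CCn1cncc1C` gives > 100 mg/kg, which is a limit of the assay and not a number. In this assay compound 1 `CC(=O)N(C)C(C)C#CCn1ccnc1` gives 3 mg/kg, and compound 3 `CC(=O)N(C)CC#CCn1cncc1C` gives 45 mg/kg.

Compound 4 `COC(=O)N(C)C(C)C#CCn1cncc1C` carries methoxy in place of methyl on a carbonyl carbon, acetyl to methoxycarbonyl (methoxy in place of methyl on a carbonyl carbon). Among the measured compounds shown here, no measured step changes this group, so the data give no direct reading of its effect or direction.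

For the measured compounds named here, two measured steps bear on it only indirectly. Methyl in place of hydrogen on an aromatic carbon is large, an at least 33-fold higher number from compound 1 to compound 2 (1.52 log units; beyond the scatter). Hydrogen in place of methyl on a saturated chain carbon is at least modest, an at least 2.2-fold lower number from compound 2 to compound 3 (0.34 log units; beyond the scatter). Compound 4 keeps both of these methyl groups, so the higher number seen in an at least 33-fold higher number from compound 1 to compound 2 (1.52 log units; beyond the scatter) is expected to persist, and no return towards compound 1 is expected.

The comparison starts from a limit, so no step beyond the scatter can be firmly expected in either direction, and this assay may again report only a limit. The expected change is a number no higher from compound 2 to compound 4 (the limit leaves the size open). The estimate for compound 4 is 100 mg/kg, with an expected range of 30 mg/kg to 300 mg/kg.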

Compound 4, dose for half-maximal effect: > 100 mg/kg
Compound 4: a limit, no number; the forecaster's own chance of this, stated with the estimate: 60%; the middle value sits exactly at the limit.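

Compound 2 and compound 4 both sit at a limit of the assay and not at a number, so no step can be read between them: the limit of > 100 mg/kg in this assay, at which 2 of the 4 values shown sit.

The compounds shown leave open what methoxycarbonyl in place of acetyl does to the dose needed, in size and in direction.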